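Mixing Two Nitrogen Substituents on a Shared Core

This account rests on a few compounds, and the source may have more. Where it says the series, first, only, none or still open, it means among the compounds named here.

Of the compounds shown here, two built on the shared core have been tested in a functional assay on HEL cells (Homo sapiens); a lower number here means that less compound is tolerated, a higher number that more compound is tolerated. Compound 1 `O=C1c2ccccc2N(COCc2ccccc2)S(=O)(=O)N1COCc1ccccc1` carries a (benzyloxy)methyl group on both ring nitrogens, and in this assay compound 1 gives 200000 nM. Compound 2 `O=C1c2ccccc2N(Cc2ccccc2Cl)S(=O)(=O)N1Cc1ccccc1Cl` carries a 2-chlorobenzyl group on both ring nitrogens instead. On these data alone, for compound 2 this assay reports only a limit, > 20000 nM, so its exact position is unknown; compound 2 stands at the limit of > 20000 nM in this assay, at which 1 of the 2 values shown sits. Compound 3 `O=C1c2ccccc2N(Cc2ccccc2Cl)S(=O)(=O)N1COCc1ccccc1` has not yet been measured and combines one group of each kind. Against compound 2, the change is benzyloxy in place of 2-chlorophenyl on a saturated chain carbon bound to an amide-type nitrogen in a ring.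

Among the measured compounds shown here, no step between measured compounds is available here, so the size of the change can only be anticipated. The step expected from compound 2 to compound 3 in this assay, a step that the limit leaves unreadable from compound 2 to compound 3, is toward a higher tolerated concentration or none beyond the scatter, leaning on compound 1 and its value of 200000 nM. Compound 3 is estimated at 100000 nM, most likely between 20000 nM and 300000 nM, and this assay may again return only a limit for it.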

Compound 3, minimum cytotoxic concentration: 200000 nM
The estimate for compound 3 lay 2.0-fold (0.30 log units) below the measured number, and the stated range covers the measured number.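

In this assay, putting 2-chlorophenyl in place of benzyloxy on a saturated chain carbon bound to a sulfonamide nitrogen in a ring gives no change at the digits printed from compound 1 to compound 3 (within the scatter). Among the compounds shown here, this is the first readable step, and it shows that at this one position the 2-chlorobenzyl and (benzyloxy)methyl groups cannot be told apart in this assay, even though one carries a chlorine and the other an oxygen in its chain. The other new step, on the chain carbon bound to the amide-type nitrogen, cannot be read, because compound 2 has only a limit: the limit of > 20000 nM in this assay, at which 1 of the 3 values shown sits.

So the compounds shown leave open whether the same swap on the amide-type nitrogen matters at all, and the finding for the sulfonamide nitrogen rests on a single pair with (benzyloxy)methyl on the other nitrogen. They also leave open how either nitrogen would respond to a group of a different kind, such as a chain ending in an amine or a carboxylic acid, in place of these two groups with their aromatic rings.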